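The source may hold more compounds than are shown below. What is called first, only, known or untested is meant among the compounds shown, and "the series" means these compounds.

Measured so far in a functional assay on M21 cells (Homo sapiens) for antiproliferative activity, read by sulforhodamine B assay, with a stated time of 48 h (a higher number here means a weaker inhibitor, a lower number a stronger inhibitor), are these values:
compound 1 `CCc1ccccc1NS(=O)(=O)c1ccc(N2CCNC2=O)cc1` at 180 nM
compound 2 `O=C1NCCN1c1ccc(S(=O)(=O)Nc2ccc3[nH]ccc3c2)cc1` at 87 nM
compound 3 `Cc1ccc(NS(=O)(=O)c2ccc(N3CCNC3=O)cc2)cc1` at 260 nM

Compound 3 sits within the scatter of compound 1, and its number lies beyond the scatter above that of compound 2. The next compound, compound 4 `O=C1NCCN1c1ccc(S(=O)(=O)Nc2ccc(I)cc2)cc1`, brings the change iodo in place of methyl on an aromatic carbon and so places iodo in place of methyl on an aromatic carbon. Going by the values given here, the one measured step that bears on this is a 1.4-fold higher number from compound 1 to compound 3 (0.16 log units; within the scatter) for 4-methylphenyl in place of 2-ethylphenyl on a sulfonamide nitrogen. Among the compounds with values here, no measured step exchanges methyl for iodo, so no shift beyond the scatter is expected in this assay and no direction is firmly favoured. The estimate means a 1.2-fold lower number from compound 3 to compound 4 (0.07 log units; within the scatter) as the expected step. Compound 4 is expected at 220 nM with a range from 80 nM to 600 nM overall.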

Compound 4, half-maximal inhibitory concentration: 260 nM
Compound 4: middle estimate off by 1.2-fold (0.07 log units), on the low side, and the stated range covers the measured number.
By their numbers in this assay, from the lowest: compound 2; then compounds 1, 3 and 4 (each within the scatter of the next).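

In this assay, iodo in place of methyl on the aromatic carbon gives no change at the digits printed from compound 3 to compound 4 (within the scatter) and so shows that this position accepts an iodine atom in place of a carbon without a change beyond the scatter. The 4-iodophenyl group, like the 4-methylphenyl group, also stays within the scatter of the 2-ethylphenyl group, with a 1.4-fold higher number from compound 1 to compound 4 (0.16 log units; within the scatter) as the step. No evidence is available on what lies behind these results.

On these data alone, whether an amine or a carboxylic acid at this position would also leave the number unmoved remains open.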